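The compounds below may be only part of what the source reports. "The series", "measured", "known", "first", "only" and "open" are said of these compounds alone.

Two compounds share a core built around a urea linking a cycloheptyl-bearing nitrogen to a pyridine: compound 1 `CSc1cc(C)nc(SC)c1NC(=O)N(Cc1cccc(Oc2ccc(Br)cc2)c1)C1CCCCCC1` and compound 2 `COc1nc(C)cc(SC)c1NC(=O)N(Cc1ccc(Oc2ccc(F)cc2)cc1)C1CCCCCC1`. In an assay for inhibition of acyl-CoA:cholesterol acyltransferase (Oryctolagus cuniculus), using microsomes (a higher number here means a weaker inhibitor, a lower number a stronger inhibitor), compound 1 gives 73 nM, and compound 2 gives 29 nM, the lower of the two numbers and a gap beyond the usual scatter, so compound 2 is the stronger inhibitor here. Compound 3 `CSc1nc(C)cc(Cl)c1NC(=O)N(Cc1ccc(Oc2ccc(F)cc2)cc1)C1CCCCCC1` differs from compound 2 by a group of 10 heavy atoms (7 carbon, 1 nitrogen, 1 sulfur, 1 chlorine; one six-membered aromatic ring with 1 hetero atom) in place of a group of 11 heavy atoms (8 carbon, 1 nitrogen, 1 oxygen, 1 sulfur; one six-membered aromatic ring with 1 hetero atom), on an amide-type nitrogen. Among the measured compounds shown here, no measured pair shows this change, so only a cautious guess is possible: the step of a 1.4-fold higher number from compound 2 to compound 3 (0.14 log units; within the scatter) is expected to stay within the scatter. Compound 3 is estimated at 40 nM, with a likely range from 12 nM to 130 nM.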

Compound 3, half-maximal inhibitory concentration: 12 nM
The estimate for compound 3 lay 3.3-fold (0.52 log units) above the measured number; the range from low to high includes it.
By their numbers in this assay, from the lowest: compound 3; then compound 2; then compound 1.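

In this assay, the ring group on the amide-type nitrogen proves sensitive to a small exchange: replacing the oxygen-bearing group with the chlorine-bearing one gives a 2.4-fold lower number from compound 2 to compound 3 (0.38 log units; beyond the scatter) as a modest gain in strength. Compounds 2 and 3 differ in this one place only, so the gain can be tied to this group. No measurement at hand explains it. Whether the chlorine alone accounts for the gain stays open. So does how a ring carrying a nitrile or an amine in its stead would score.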